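Butoxy for trifluoromethyl on the aryl amine of the amidoxime series

The source may report more compounds than this note shows. Statements on the series, on what has been measured and on what is new or still open speak of the compounds shown alone.

Compound 1 `O/N=C(/Nc1ccccc1)c1ccc2occc2c1` carries the shared core with an unsubstituted aryl amine; in an assay on tissue (HeLa cells) for inhibition of Indoleamine 2,3-dioxygenase 1 (Homo sapiens), read by spectrophotometry (a higher number here means a weaker inhibitor, a lower number a stronger inhibitor), compound 1 gives 19000 nM. For the measured compounds named here, compound 2 `O/N=C(/Nc1cccc(C(F)(F)F)c1)c1ccc2occc2c1` differs by a trifluoromethyl on an aromatic carbon, and in this assay compound 2 gives 1900 nM, the lowest of the two numbers measured so far. Going by the values given here, the one step measured is a 10-fold lower number from compound 1 to compound 2 (1.00 log units; beyond the scatter).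

Compound 3 `CCCCOc1cccc(N/C(=N/O)c2ccc3occc3c2)c1` is not yet measured. It differs from compound 2 by butoxy in place of trifluoromethyl on an aromatic carbon. Among the compounds with values here, no measured step exchanges one substituent for another at this carbon; the only step that bears on the site is the one from compound 1 to compound 2, which shows that a group on this carbon, meta to a large group, gives a lower number than hydrogen. On these data alone, whether butoxy holds that gain is unknown, so the expected step in this assay is small, in either direction, and may fall within the scatter.

In this assay compound 3 is therefore expected to give about 1500 nM, estimated between 400 nM and 6000 nM, which would mean an estimated step of a 1.3-fold lower number from compound 2 to compound 3 (0.10 log units; within the scatter).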

Compound 3, half-maximal inhibitory concentration: > 30000 nM
Compound 3: only a limit was reported; the forecaster's own chance of this, stated with the estimate: 5%; at least 20-fold (1.30 log units) between middle value and limit.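

Compound 3 is reported in this assay only as a limit, not as a number: the limit of > 30000 nM in this assay, at which 1 of the 3 values shown sits.

Before this result, the only step at this aromatic carbon showed that trifluoromethyl gave a lower number than hydrogen, which left open whether other groups would do the same. Butoxy in place of trifluoromethyl gives an at least 15-fold higher number from compound 2 to compound 3 (1.19 log units; beyond the scatter), so the gain at this carbon does not hold for every group, and within these three compounds the outcome depends on which group is placed there. Butoxy in place of hydrogen gives an at least 1.5-fold higher number from compound 1 to compound 3 (0.19 log units; that floor lies within the scatter), so butoxy keeps none of the gain seen with trifluoromethyl, though the floor of this step does not establish that butoxy is worse than hydrogen.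

On these data alone, the true size of both steps stays unknown, as the value for compound 3 is only a limit. Methoxy, a butyl chain or a chlorine on the same aromatic carbon would help show whether the loss follows the ether oxygen, the length of the chain or something else about butoxy.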